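Adding a Methoxy Group: Expected Cytotoxicity of Compound 3

A few compounds are considered here, and "the series" means these few. Any claim that something is new, unique, unknown or untested is made for them only; others in the source may bear on it.

Measured compounds:
compound 1, `c1ccc(Cn2cnc3c(-c4ccco4)nccc32)cc1`: > 25000 nM
compound 2, `COc1ccc2nc(C)cc(OCC(=O)Nc3ccccc3)c2c1`: > 155000 nM

Of the compounds shown here, two have been tested in an ADME assay on HepG2 cells (Homo sapiens) for cytotoxicity, read by trypan blue exclusion, with a stated time of 48 h, in the presence of a further agent that is not named here; a lower number here means that less compound is tolerated, a higher number that more compound is tolerated. For compound 1, the value > 25000 nM is a limit of the assay and not a number. For compound 2, the value > 155000 nM is likewise a limit and not a number. Compound 2 therefore stands at one of two limits: the limit of > 155000 nM in this assay, at which 1 of the 2 values shown sits, and the limit of > 25000 nM in this assay, at which 1 of the 2 values shown sits, are all that is known, and neither compound carries a numbered value. Compound 3, `COc1cccc(NC(=O)COc2cc(C)nc3ccc(OC)cc23)c1`, differs from compound 2 by methoxy in place of hydrogen on an aromatic carbon. Among the measured compounds shown here, no step between measured compounds covers this change, so nothing measured points either way. The expected step is a number no higher from compound 2 to compound 3 (the limit leaves the size open), none beyond the scatter, since only limits are available. Compound 3 is expected to give about 155000 nM in this assay, within 60000 nM to 400000 nM, most probably reported once more as a limit.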

Compound 3, half-maximal cytotoxic concentration: 43000 nM
Compound 3: middle estimate off by 3.6-fold (0.56 log units), on the high side; measured number outside the range, below it.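

Among the compounds shown here, compound 3 gives the first numbered value in this assay, so the comparison no longer rests on limits alone. Going from phenyl to 3-methoxyphenyl gives an at least 3.6-fold lower number from compound 2 to compound 3 (0.55 log units; beyond the scatter) and shows that this place on the aromatic ring is not silent, since methoxy in place of hydrogen lowers the tolerated concentration. From the compounds shown here alone, the full size of the step stays open, because compound 2 is held only by a limit: the limit of > 155000 nM in this assay, at which 1 of the 3 values shown sits.

Going by these compounds, whether another group at this place, such as an amine or a carboxylic acid, would lower the number in the same way remains open. Also open, on these data alone, are whether methoxy at another place on this ring would do the same and what underlies the change.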